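The source may report more compounds than this note shows. Statements on the series, on what has been measured and on what is new or still open speak of the compounds shown alone.

Compound 1 `Nc1cc(N)c2nc(-c3ccccc3)c(Oc3ccc(Cl)c(Cl)c3)nc2c1`: 15500 nM
Compound 2 `CCOC(=O)[C@H](CCC(=O)O)NC(=O)c1ccc(CNc2nc3cc(N)cc(N)c3nc2-c2ccccc2)cc1`: 45700 nM
Compound 3 `COc1cc(CNc2nc3cc(N)cc(N)c3nc2-c2ccccc2)cc(OC)c1OC`: 8710 nM

In a functional assay on NCI-H23 cells (Homo sapiens) for inhibition, read by sulforhodamine B assay, with a stated time of 48 h (a higher number here means a weaker inhibitor of growth, a lower number a stronger inhibitor of growth), compound 1 gives 15500 nM, the second highest of the three numbers shown. Compound 3 gives 8710 nM, which lies within the usual scatter of that result, while compound 2 gives 45700 nM, a gap that goes beyond the scatter. Compound 4 `Nc1cc(N)c2nc(-c3ccccc3)c(Sc3ccc(F)cc3)nc2c1` differs from compound 1 in one place: (4-fluorophenyl)sulfanyl in place of 3,4-dichlorophenoxy on an aromatic carbon. Within the data shown here, no measured pair shows an exchange of this kind, so the size of the step cannot be read from the numbers at hand. The step from compound 1 to compound 4 is expected to be small, a 1.0-fold lower number from compound 1 to compound 4 (0.01 log units; within the scatter), with no direction that clearly goes beyond the scatter. Compound 4 is therefore estimated at 15000 nM, with a range from 5000 nM to 45000 nM.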

Compound 4, concentration for 50% growth inhibition: 19100 nM
Beside the measured number, compound 4's estimate is 1.3-fold (0.10 log units) below it; the measured number falls inside the stated range.
By their numbers in this assay, from the lowest: compounds 3, 1 and 4 (each within the scatter of the next, the first and the last beyond it); then compound 2.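

In this assay, placing (4-fluorophenyl)sulfanyl on this aromatic carbon in place of 3,4-dichlorophenoxy gives a 1.2-fold higher number from compound 1 to compound 4 (0.09 log units; within the scatter), a step within the scatter. At this position, next to the ring nitrogen and ortho to a phenyl group, the two groups cannot be told apart by their numbers, although they differ in both linking atom and halogens. No measurement here explains this result.

On these data alone, because the linking atom and the halogens differ together, the contribution of each remains unknown. As far as these compounds go, it also remains open how a hydroxyl or a short alkyl chain would behave at this position.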